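The compounds below may be only part of what the source reports. "The series", "measured", "known", "first", "only" and "open" are said of these compounds alone.

In a functional assay on SW-620 cells (Homo sapiens) for antiproliferative activity, read by MTT assay, with a stated time of 72 h (on this read-out higher numbers stand for weaker inhibition and lower numbers for stronger inhibition), compound 3 `O=C1O[C@H]([C@@H](O)Cn2ccnn2)C(OCc2ccccc2)=C1OCc1ccccc1` gives > 100000 nM, which is a limit and not a number. That puts it at the limit of > 100000 nM in this assay, at which 1 of the 3 values shown sits.

Compound 4 `O=C1O[C@H]([C@@H](O)Cn2cc(CCO)nn2)C(OCc2ccccc2)=C1OCc1ccccc1` differs from it at one place: 2-hydroxyethyl in place of hydrogen on an aromatic carbon, (2-hydroxyethyl in place of hydrogen on an aromatic carbon). The ring is the five-membered aromatic ring with 3 nitrogen.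

The same carbon carries 4-pentylphenyl in compound 1 `CCCCCc1ccc(-c2cn(C[C@H](O)[C@H]3OC(=O)C(OCc4ccccc4)=C3OCc3ccccc3)nn2)cc1`, which gives 12200 nM, and cyclopropyl in compound 2 `O=C1O[C@H]([C@@H](O)Cn2cc(C3CC3)nn2)C(OCc2ccccc2)=C1OCc1ccccc1`, which gives 54200 nM. Among the measured compounds shown here, three measured steps bear on the change. Removing the substituent altogether gives an at least 8.1-fold higher number from compound 1 to compound 3 (0.91 log units; beyond the scatter), and the smaller comparison gives an at least 1.8-fold higher number from compound 2 to compound 3 (0.26 log units; that floor lies within the scatter). Between the two substituted compounds lies a 4.4-fold higher number from compound 1 to compound 2 (0.65 log units; beyond the scatter).

Only compound 1 is clearly separated from both others, so a large gain from a group with no ring is not expected. Compound 2 at 54200 nM is the more useful guide, and its gap to compound 3 is not shown to lie beyond the scatter. A small move towards a lower number is therefore expected at best, and a second reading at the limit is quite possible. The expected change is an at least 1.3-fold lower number from compound 3 to compound 4 (0.12 log units; that floor lies within the scatter). Compound 4 is estimated at 75000 nM, with an expected range of 35000 nM to 100000 nM.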

Compound 4, half-maximal inhibitory concentration: > 100000 nM
Compound 4 gave a limit, no number (the forecaster's own chance of this, stated with the estimate: 50%); middle value at least 1.3-fold (0.12 log units) away from the limit.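

In this assay compound 4 gives > 100000 nM, which is a limit and not a number, so 2-hydroxyethyl on this aromatic carbon does not bring the series into the measurable range. Among the compounds shown here, the result gives an at least 1.8-fold higher number from compound 2 to compound 4 (0.26 log units; that floor lies within the scatter), whose floor stays within the scatter, and an at least 8.1-fold higher number from compound 1 to compound 4 (0.91 log units; beyond the scatter), which makes compound 1 the only compound with steps to all three others printed as beyond the scatter. The upper end of the read-out now holds a second compound at this position, and the step between the two compounds at the limit cannot be read: the limit of > 100000 nM in this assay, at which 2 of the 4 values shown sit.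

As far as these compounds go, it remains open how far compound 3 and compound 4 actually lie apart, and whether cyclopropyl in compound 2 is truly separated from either of them. Also open, from the compounds shown here alone, is whether the lower number of compound 1 needs both parts of 4-pentylphenyl, which an unsubstituted phenyl or a straight pentyl chain on the same carbon would test, and whether an amine or a carboxylic acid at the end of a short chain would give a reading at all.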